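Ester series: acrylamide to crotonamide on the anilide

A few compounds are considered here, and "the series" means these few. Any claim that something is new, unique, unknown or untested is made for them only; others in the source may bear on it.

Working notes on the shared core of compound 3 `C=CC(=O)Nc1ccc(Cn2nc(-c3ccc(Oc4ccccc4)cc3)cc2C(=O)OCC)cc1`. In a functional assay on Maver1 cells (Homo sapiens) for inhibition, read by luminescence and CellTiter-Glo, with a stated time of 72 h (on this read-out higher numbers stand for weaker inhibition and lower numbers for stronger inhibition), compound 3 gives 13300 nM, the highest of the two numbers recorded for this read-out. Compound 2 `CCOC(=O)c1cc(-c2ccc(Oc3ccccc3)cc2)nn1Cc1cccc(NC(=O)CCl)c1` gives 500 nM in this assay, and the step of a 27-fold higher number from compound 2 to compound 3 (1.42 log units; beyond the scatter) is large. Compound 1 `C/C=C/C(=O)Nc1ccc(Cn2nc(-c3ccc(Oc4ccccc4)cc3)cc2C(=O)O)cc1` reaches only the assay limit of > 60000 nM in this assay, at which 1 of the 3 values shown sits, in this assay, so compound 1 gives > 60000 nM, a limit rather than a number.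

Compound 4 `C/C=C/C(=O)Nc1ccc(Cn2nc(-c3ccc(Oc4ccccc4)cc3)cc2C(=O)OCC)cc1` is not yet measured. It differs from compound 3 in one place: prop-1-en-1-yl in place of vinyl on a carbonyl carbon. Within the data shown here, no measured step matches this change; the one measured step, from compound 2 to compound 3, alters a different group at a different ring position and so bears on it only loosely. The expected step of a 2.3-fold higher number from compound 3 to compound 4 (0.35 log units; beyond the scatter) is therefore a modest move toward a higher number, not far beyond the scatter. Compound 4 is estimated at 30000 nM in this assay, with a range from 10000 nM to 80000 nM.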

Compound 4, half-maximal inhibitory concentration: > 60000 nM
Compound 4 ended at the assay's limit; the forecaster's own chance of this, stated with the estimate: 30%; middle value at least 2.0-fold (0.30 log units) from the limit.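

In this assay, among these compounds, prop-1-en-1-yl in place of vinyl on a carbonyl carbon gives an at least 4.5-fold higher number from compound 3 to compound 4 (0.65 log units; beyond the scatter), the first measured step at this place, and it moves the ethyl ester series in the direction of weaker inhibition. Putting 4-(((prop-1-en-1-yl)carbonyl)amino)phenyl in place of 3-(((chloromethyl)carbonyl)amino)phenyl gives an at least 120-fold higher number from compound 2 to compound 4 (2.07 log units; beyond the scatter), a wider gap than the one seen with the vinyl amide. Compound 4 and compound 1 both stand at a limit rather than a number, so the step between them cannot be read: the limit of > 60000 nM in this assay, at which 2 of the 4 values shown sit.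

From the compounds shown here alone, how an amine or a longer chain on the end of the prop-1-en-1-yl group would read stays open. Also open, going by these compounds, is how the gap to the chloromethyl amide divides between the group on the carbonyl carbon and the placement on the phenyl, since the two change together in that step.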